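A few compounds are considered here, and "the series" means these few. Any claim that something is new, unique, unknown or untested is made for them only; others in the source may bear on it.

For the measured compounds named here, compound 1 `ClCc1ccccc1Cn1cnc2c(Cl)nc(Cl)nc21` stands lowest of the three numbers measured so far, giving 1510 nM in a functional assay on UO-31 cells (Homo sapiens) for cytotoxicity, read by sulforhodamine B assay, with a stated time of 48 h; a higher number here means a weaker inhibitor of growth, a lower number a stronger inhibitor of growth. Compound 3 `ClCc1ccccc1Cn1cnc2ncnc(Cl)c21` gives 10700 nM, and compound 2 `Nc1nc(Cl)c2ncn(Cc3ccc(CCl)cc3)c2n1` gives 25100 nM; both of these differences from compound 1 lie beyond the scatter. Compound 4 `Nc1nc(Cl)c2ncn(Cc3ccccc3CCl)c2n1` has not yet been measured in this assay. It differs from compound 1 in one place: amino in place of chloro on an aromatic carbon. Going by the values given here, no step between measured compounds that differ in one place is available, so the size of this change can only be guessed. Compound 2, which also carries an amino group on its core, gives 25100 nM, so a rise in the number beyond the scatter is expected. Compound 4 is therefore estimated at 12000 nM, with a range from 4000 nM to 40000 nM, expected to correspond to a 7.9-fold higher number from compound 1 to compound 4 (0.90 log units; beyond the scatter).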

Compound 4, concentration for total growth inhibition: 44700 nM
For compound 4 the middle estimate is 3.7-fold (0.57 log units) below the measured one; the measured number lies above the stated range.
By their numbers in this assay, from the lowest: compound 1; then compound 3; then compounds 2 and 4 (each within the scatter of the next).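

In this assay, amino in place of chloro on an aromatic carbon gives a 30-fold higher number from compound 1 to compound 4 (1.47 log units; beyond the scatter) and this large step lies beyond the scatter. For the compounds shown here, it is the first step read between compounds that differ in one place, and it shows that the number at this position, between two ring nitrogen atoms, responds strongly to this change. No evidence here accounts for the size of the step.

Going by these compounds, whether a methoxy group or a methylamino group at this position would stay nearer to the chloro compound remains open.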